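The source may report more compounds than this note shows. Statements on the series, on what has been measured and on what is new or still open speak of the compounds shown alone.

- compound 1 `COc1ccc([C@H]2CC(=O)N(c3cccc(C(F)(F)F)c3)C2)cc1OC1CCCC1`: > 10000 nM (a limit)
- compound 2 `COc1ccc([C@H]2CC(=O)N(c3cccc(NS(=O)(=O)c4ccc(F)cc4)c3)C2)cc1OC1CCCC1`: > 10000 nM (a limit)

In a functional assay on HEK293 cells (Homo sapiens) for cytotoxicity (a higher number here means that more compound is tolerated, a lower number that less compound is tolerated), compound 2 stands at a limit, > 10000 nM, and so gives no exact number. Compound 1 and compound 2 both rest on (the limit of > 10000 nM in this assay, at which 2 of the 2 values shown sit). Compound 3 `COc1ccc([C@H]2CC(=O)N(c3cccc(NS(=O)(=O)c4c(Br)nn(C)c4Cl)c3)C2)cc1OC1CCCC1` alters the group on the sulfonyl sulfur of compound 2: 3-bromo-5-chloro-1-methyl-1H-pyrazol-4-yl in place of 4-fluorophenyl on a sulfonyl sulfur, with 3-bromo-5-chloro-1-methyl-1H-pyrazol-4-yl in place of 4-fluorophenyl. Among the measured compounds shown here, the one measured step bearing on this is a step that the two limits leave unreadable from compound 1 to compound 2, which brought in the sulfonyl group but yields no size. With no readable step to draw on, no change beyond the scatter is expected in this assay, and another limit is the likeliest report. The expected change is a step that the limit leaves unreadable from compound 2 to compound 3. For compound 3 the estimated value is 12000 nM, with an expected range from 5000 nM to 30000 nM.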

Compound 3, half-maximal cytotoxic concentration: > 10000 nM
Compound 3: a limit, no number; the forecaster's own chance of this, stated with the estimate: 80%; the middle value lies beyond the limit too.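

No step can be read among compound 1, compound 2 and compound 3, each of which gives only a limit in this assay: the limit of > 10000 nM in this assay, at which 3 of the 3 values shown sit.

The compounds shown leave open whether exchanging the group on the sulfonyl sulfur, or replacing trifluoromethyl, shifts the tolerated concentration at all.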